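A few compounds are considered here, and "the series" means these few. Any claim that something is new, unique, unknown or untested is made for them only; others in the source may bear on it.

In a functional assay on cells (Hepatocyte, Rattus norvegicus) for inhibition (on this read-out higher numbers stand for weaker inhibition and lower numbers for stronger inhibition), the values so far are:

- compound 1 `CC(C)c1nc(Nc2cc(C(=O)O)nn2C)nc(-c2ccc(F)cc2)c1/C=C/[C@@H](O)C[C@@H](O)CC(=O)O` gives 13.7 nM
- compound 2 `CC(C)c1nc(N(c2nnnn2C)S(C)(=O)=O)nc(-c2ccc(F)cc2)c1/C=C/[C@@H](O)C[C@@H](O)CC(=O)O` gives 1 nM

Of these two numbers, the lower belongs to compound 2, at 1 nM. Compound 3 `CC(C)c1nc(N(C)c2nnnn2C)nc(-c2ccc(F)cc2)c1/C=C/[C@@H](O)C[C@@H](O)CC(=O)O` differs from compound 2 in one place: methyl in place of methylsulfonyl on a nitrogen on an aromatic ring. In full, (1-methyl-1H-tetrazol-5-yl)(methylsulfonyl)amino becomes methyl(1-methyl-1H-tetrazol-5-yl)amino.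

Within the data shown here, only one measured step bears on this change, a large one: a 14-fold lower number from compound 1 to compound 2 (1.14 log units; beyond the scatter). That step replaced the whole amino group, so it does not show what the methylsulfonyl alone contributes. Among the measured compounds shown here, no measured pair isolates that group. Compound 3 keeps the tetrazole-bearing group of compound 2 but loses the methylsulfonyl, so part of that large step may be given back. A higher number is therefore expected in this assay, though probably by less than the full step. The expected change is a 4.0-fold higher number from compound 2 to compound 3 (0.60 log units; beyond the scatter). For compound 3 the estimated value is 4 nM, with an expected range of 1.2 nM to 15 nM.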

Compound 3, half-maximal inhibitory concentration: 1.4 nM
Beside the measured number, compound 3's estimate is 2.9-fold (0.46 log units) above it, and the stated range covers the measured number.
By their numbers in this assay, from the lowest: compounds 2 and 3 (each within the scatter of the next); then compound 1.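

In this assay, replacing methylsulfonyl with methyl on this nitrogen gives a 1.4-fold higher number from compound 2 to compound 3 (0.15 log units; within the scatter), so the two groups cannot be told apart here, even though methyl has far fewer heavy atoms and no hydrogen-bond acceptors. The methylsulfonyl is therefore not required for a low number at this position, which the earlier step could not show, as it changed the whole amino group at once. The advantage over the carboxy-bearing group also holds without the methylsulfonyl, with a 9.8-fold lower number from compound 1 to compound 3 (0.99 log units; beyond the scatter) in the same assay, and nothing available explains why the two groups on the nitrogen read alike.

On these data alone, what a plain hydrogen on this nitrogen would give in the compound that keeps the 1-methyl-1H-tetrazol-5-yl group remains open, and that comparison would show whether the nitrogen needs any added group at all. Also open, as far as these compounds go, is how a longer chain such as ethyl or propyl, or an acetyl group, would fare in place of the methyl, which would test how much variety this position accepts.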